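This account rests on a few compounds, and the source may have more. Where it says the series, first, only, none or still open, it means among the compounds named here.

Compound 1 `O=C1c2ccccc2N(Cc2ccccc2)S(=O)(=O)N1Cc1ccc(Cl)cc1` gives 27800 nM in a functional assay on CCRF-CEM cells (Homo sapiens) for inhibition; a lower number here means that less compound is tolerated, a higher number that more compound is tolerated. Compound 2 `O=C1c2ccccc2N(Cc2ccccc2Cl)S(=O)(=O)N1COCc1ccccc1`, which carries the benzyloxy group on the other ring nitrogen, gives 22200 nM in this assay. For compound 3 `O=C1c2ccccc2N(Cc2ccccc2)S(=O)(=O)N1Cc1ccccc1Cl` this assay reports only a limit, > 250000 nM. Compound 3 thus stands at the top of the numbers shown, with no exact value of its own. For the measured compounds named here, the one measured step at the same place, an at least 8.9-fold higher number from compound 1 to compound 3 (0.95 log units; beyond the scatter), rests on that limit of > 250000 nM in this assay, at which 1 of the 3 values shown sits, and is therefore known only as a lower bound for its size.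

Compound 4 `O=C1c2ccccc2N(Cc2ccccc2)S(=O)(=O)N1COCc1ccccc1` differs from compound 3 in one place: benzyloxy in place of 2-chlorophenyl on a saturated chain carbon bound to an amide-type nitrogen in a ring. Going by the values given here, no measured step exchanges a chlorophenyl for a benzyloxy group at this position, so the step from compound 1 to compound 3 is the only guide, and it shows that the 2-chlorophenyl group lifted the number well beyond the scatter. Removing that group is expected to bring the number back down, and compound 4 is expected to show an at least 8.3-fold lower number from compound 3 to compound 4 (0.92 log units; beyond the scatter). The estimate for compound 4 in this assay is 30000 nM, with a range from 10000 nM to 150000 nM, near the values of compound 1 and compound 2.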

Compound 4, half-maximal cytotoxic concentration: 100000 nM
Estimate against measurement, compound 4: 3.3-fold (0.52 log units) below; measured number inside the range.
By their numbers in this assay, from the lowest: compounds 2 and 1 (each within the scatter of the next); then compound 4. At a limit, above all of these: compound 3.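

In this assay, the first exchange of the 2-chlorophenyl for benzyloxy at this place gives a step that can be read only as a bound, an at least 2.5-fold lower number from compound 3 to compound 4 (0.39 log units; beyond the scatter), and the reason is a limit on compound 3: the limit of > 250000 nM in this assay, at which 1 of the 4 values shown sits.

Benzyloxy also separates from the 4-chlorophenyl group at the same place, a 3.6-fold higher number from compound 1 to compound 4 (0.56 log units; beyond the scatter), so among these three groups the order of the numbers runs from 4-chlorophenyl through benzyloxy to 2-chlorophenyl, which stands at the limit. With benzyloxy kept in place, the step of a 4.5-fold higher number from compound 2 to compound 4 (0.65 log units; beyond the scatter) shows that hydrogen in place of chloro on an aromatic carbon also moves the number beyond the scatter, so this position is not the only one that matters in this series.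

On these data alone, how far compound 3 really lies from the others remains open, and so does whether the chloro exchange would have the same effect with a group other than benzyloxy at this position. A plain phenyl group at this position, or a longer chain ending in an amine or a carboxylic acid, would show where those groups fall in this order.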